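Cyclopropyl for tert-butyl: a step without precedent

The source may hold more compounds than are shown below. What is called first, only, known or untested is meant among the compounds shown, and "the series" means these compounds.

Of the compounds shown here, three of one series have been measured in an assay on isolated protein for inhibition of serine/threonine-protein kinase 10 (Homo sapiens), read by thermal shift assay, tested at 10 uM; on this read-out lower numbers stand for weaker stabilisation of the target and higher numbers for stronger stabilisation of the target against heat. Compound 1 `CC(C)(C)c1cc(NC(=O)Nc2ccc(Cl)cc2)n(-c2ccc(C(F)(F)F)cc2)n1` gives -0.6 degrees C, compound 2 `CC(C)(C)c1cc(NC(=O)Nc2ccc(Cl)cc2)n(-c2ccc(OC(F)(F)F)cc2)n1` gives 0 degrees C, and compound 3 `CC(C)(C)c1cc(NC(=O)Nc2ccc(Cl)cc2)n(-c2ccc(C#N)cc2)n1` gives 2.2 degrees C. Compound 2 thus stands second highest of the three, with compound 1 within the scatter of it and compound 3 beyond it. Each of the measured steps alters one group on the same aromatic carbon of the shared core: a number 0.60 degrees C higher from compound 1 to compound 2 (within the scatter), a number 2.8 degrees C higher from compound 1 to compound 3 (beyond the scatter), and a number 2.2 degrees C higher from compound 2 to compound 3 (beyond the scatter). Compound 4 `O=C(Nc1ccc(Cl)cc1)Nc1cc(C2CC2)nn1-c1ccc(OC(F)(F)F)cc1` has not yet been measured. It differs from compound 2 at another place: cyclopropyl in place of tert-butyl on an aromatic carbon. For the measured compounds named here, none of the measured steps touches this group, so no step bears directly on it; the data only show that a single change on this core can move the read-out modestly. Going by the values given here, with no precedent, the author expects only a small step, a number 0.50 degrees C lower from compound 2 to compound 4 (within the scatter), and claims no direction beyond the scatter. Compound 4 is therefore estimated at -0.5 degrees C, within -2.5 degrees C to 1.5 degrees C.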

Compound 4, shift of the target's melting temperature: 0 degrees C
For compound 4 the middle estimate is 0.50 degrees C below the measured one; the range from low to high includes it.
By their numbers in this assay, from the lowest: compounds 1, 2 and 4 (each within the scatter of the next); then compound 3.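

In this assay, this position now has a reading of its own: cyclopropyl in place of tert-butyl gives no change at the digits printed from compound 2 to compound 4 (within the scatter), although the group shrinks from 4 heavy atoms to 3 and gains a three-membered non-aromatic ring. For the compounds shown here, the earlier compounds varied only the group on another aromatic carbon, where cyano in place of trifluoromethoxy gives a number 2.2 degrees C higher from compound 2 to compound 3 (beyond the scatter), so this is the first sign that a change elsewhere on the shared core can leave the read-out in place, at least with trifluoromethoxy present. Nothing available explains why the read-out holds here.

As far as these compounds go, whether the same exchange would read alike on compound 3, which carries cyano, stays open. So does the effect of a carboxylic acid, an amine or a longer alkyl chain at this position.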